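The compounds below may be only part of what the source reports. "The series", "measured", "known", "first", "only" and "open" are said of these compounds alone.

Measured so far:
- compound 1 `O=C(Nc1sc2c(c1C(=O)NNc1ccccc1)CCCCC2)NS(=O)(=O)c1ccccc1`: in a functional assay on cells (Cancer cell lines, Homo sapiens) for inhibition, with a stated time of 48 h (a higher number here means a weaker inhibitor of growth, a lower number a stronger inhibitor of growth), compound 1 gives > 100000 nM, a limit of the assay and not a number.
- compound 2 `O=C(Nc1sc2c(c1C(=O)NNc1ccc(Br)cc1)CCCCC2)NS(=O)(=O)c1ccccc1`: in this assay compound 2 gives > 100000 nM, again a limit of the assay.

Compound 2 therefore stands only at a limit, with no measured number of its own. Within the data shown here, the one measured step, bromo in place of hydrogen on an aromatic carbon, from compound 1 to compound 2 a step that the two limits leave unreadable from compound 1 to compound 2 cannot be sized, because both values sit at the limit of > 100000 nM in this assay, at which 2 of the 2 values shown sit.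

Compound 3 `O=C(Nc1sc2c(c1C(=O)N1CCN(c3ccccc3)CC1)CCCCC2)NS(=O)(=O)c1ccccc1` differs from compound 2 by 4-phenylpiperazin-1-yl in place of ((4-bromophenyl)amino)amino on a carbonyl carbon. Among the measured compounds shown here, no measured step bears on this change, since the single step known is unreadable. On that basis compound 3 is expected to give about 80000 nM in this assay, within a range from 15000 nM to 300000 nM. The step from compound 2 to compound 3 is thus estimated as an at least 1.2-fold lower number from compound 2 to compound 3 (0.09 log units; that floor lies within the scatter), with a real chance that only a limit is reported.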

Compound 3, concentration for 50% growth inhibition: 60300 nM
Compound 3: middle estimate off by 1.3-fold (0.12 log units), on the high side; the range from low to high includes it.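

At this carbonyl carbon, 4-phenylpiperazin-1-yl gives the only measured number among the compounds shown: in this assay, compound 3 gives 60300 nM. Set against ((4-bromophenyl)amino)amino and anilinoamino, this change gives the first readable steps at this position, an at least 1.6-fold lower number from compound 2 to compound 3 (0.21 log units; that floor lies within the scatter) and an at least 1.6-fold lower number from compound 1 to compound 3 (0.21 log units; that floor lies within the scatter), so the floor of each step stays within the scatter even though the direction is printed. The full size of these steps cannot be read, and the bromo step stays unreadable, because the other values are limits of the assay: the limit of > 100000 nM in this assay, at which 2 of the 3 values shown sit.

As far as these compounds go, it remains open how the number would move at this carbonyl carbon with morpholin-4-yl or a simple dialkylamine. From the compounds shown here alone, it is also open whether a bromo group on the phenyl ring of 4-phenylpiperazin-1-yl would change the value of compound 3.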